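The source may hold more compounds than are shown below. What is called first, only, known or untested is meant among the compounds shown, and "the series" means these compounds.

Working notes on the series. Of the compounds shown here, three have been measured in a functional assay on PC-3 cells (Homo sapiens) for antiproliferative activity, read by sulforhodamine B assay, with a stated time of 48 h; a higher number here means a weaker inhibitor, a lower number a stronger inhibitor. Compound 1 `C[C@H]1N=C2C[C@H]3C[C@H](C3(C)C)[C@@]2(C)OC1=O` gives 42000 nM in this assay, the lowest of the three numbers. Compound 2 `CC1(C)[C@H]2CC[C@]1(C)[C@H]1OC(=O)CN=C21` gives 145000 nM in this assay. Compound 3 `C[C@@H]1N=C2C[C@@H]3C[C@@H](C3(C)C)[C@]2(C)OC1=O` gives 149000 nM in this assay. For the measured compounds named here, the only step between compounds that differ in one place is a 3.5-fold higher number from compound 1 to compound 3 (0.55 log units; beyond the scatter); the step rests on (the fact that compounds 1 and 3 differ only in the configuration as drawn), nothing else separates the two. Going by the values given here, compound 2 and compound 1 have different cores, and no single step between them is drawn, so their two values are compared only as they stand, with compound 2 the higher number.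

The next compound to be measured is compound 4 `CC1(C)[C@H]2CC3=NCC(=O)O[C@]3(C)[C@@H]1C2`. Relative to compound 1 the change is hydrogen in place of methyl on a saturated ring carbon. Among the compounds with values here, no measured step touches this position; the one measured step concerns configuration alone and so does not bear on the removal of a methyl group. Absent a comparable step, a change within the scatter or a modest rise in the number is expected, with a 1.5-fold higher number from compound 1 to compound 4 (0.19 log units; within the scatter) as the working figure. For compound 4 in this assay the estimate is 65000 nM, within a range from 25000 nM to 170000 nM.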

Compound 4, half-maximal inhibitory concentration: > 300000 nM
Compound 4: a limit, no number; the forecaster's own chance of this, stated with the estimate: 10%; at least 4.6-fold (0.66 log units) between middle value and limit.
By their numbers in this assay, from the lowest: compound 1; then compounds 2 and 3 (each within the scatter of the next). At a limit, above all of these: compound 4.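

In this assay compound 4 stands at > 300000 nM, which is a limit of the assay and not a number. The saturated ring carbon next to the ring nitrogen and two ring bonds from the ring oxygen is now shown to be sensitive to substitution, not only to configuration: hydrogen in place of methyl gives an at least 7.1-fold higher number from compound 1 to compound 4 (0.85 log units; beyond the scatter), so this single methyl group is tied to the measurable antiproliferative value of compound 1, and this step, unlike the earlier one, concerns a change of group rather than a drawn configuration. The true size of this step remains unknown, and the figure is only a bound set by the assay: the limit of > 300000 nM in this assay, at which 1 of the 4 values shown sits.

The series gives no reason for the loss, and the result does not show whether the same replacement would have a similar outcome on the mirror-image framework of compound 3. Also open, on these data alone, is whether an ethyl group, a longer chain or an amine on this saturated ring carbon would keep, lower or raise the number seen with methyl.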